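Saturating the ethenyl linker of compound 3

The compounds below may be only part of what the source reports. "The series", "measured", "known", "first", "only" and "open" are said of these compounds alone.

Compound 1 `COc1ccc(-c2cncc(C(=O)N(C)C)c2)cc1S(=O)(=O)Nc1cccc(NCCNC(=O)c2cccc(C)c2)c1` in a functional assay on CHO-RD-HGA16 cells for agonist activity at Orexin receptor type 2 (Homo sapiens), read by fluorescence and calcium flux, with a stated time of 30 min (a lower number here means that less compound is needed, a higher number that more compound is needed for the effect), gives 619 nM, and compound 2 `COc1ccc(-c2csc(C(=O)N(C)C)c2)cc1S(=O)(=O)Nc1cccc(NCCNC(=O)c2cccc(C)c2)c1` gives 166 nM in this assay, a step of a 3.7-fold lower number from compound 1 to compound 2 (0.57 log units; beyond the scatter). Compound 3 `COc1ccc(/C=C/C(=O)N(C)C)cc1S(=O)(=O)Nc1cccc(NCCNC(=O)c2cccc(C)c2)c1` reaches only a limit in this assay, > 10000 nM. That limit is the limit of > 10000 nM in this assay, at which 1 of the 3 values shown sits. The steps of an at least 16-fold higher number from compound 1 to compound 3 (1.20 log units; beyond the scatter) and an at least 60-fold higher number from compound 2 to compound 3 (1.77 log units; beyond the scatter) mark the large loss on going from either ring to the open chain. Compound 4 `COc1ccc(CCC(=O)N(C)C)cc1S(=O)(=O)Nc1cccc(NCCNC(=O)c2cccc(C)c2)c1` differs from compound 3 by 2-(dimethylcarbamoyl)ethyl in place of 2-(dimethylcarbamoyl)ethenyl on an aromatic carbon. For the measured compounds named here, no measured step covers a saturated chain. Only the two large steps to compound 3 bear on it, and the chain in compound 4 stays without a ring. A step that the limit leaves unreadable from compound 3 to compound 4 is therefore expected, none beyond the scatter. Compound 4 is estimated at 15000 nM, between 4000 nM and 60000 nM, most likely again a limit.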

Compound 4, half-maximal effective concentration: > 10000 nM
Compound 4: no number, only a limit; the forecaster's own chance of this, stated with the estimate: 75%; the middle value is on the limit's open side.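

Saturating the chain brings no measurable gain at this position: compound 4, like the compound before it, gives only a limit in this assay, > 10000 nM. The steps of an at least 60-fold higher number from compound 2 to compound 4 (1.77 log units; beyond the scatter) and an at least 16-fold higher number from compound 1 to compound 4 (1.20 log units; beyond the scatter) place the 2-(dimethylcarbamoyl)ethyl chain, as with the 2-(dimethylcarbamoyl)ethenyl chain, far from both ring compounds, so removing the chain's double bond does not close that gap. The step between the two open chains cannot be read, since both sit at the limit: the limit of > 10000 nM in this assay, at which 2 of the 4 values shown sit.

Open, going by these compounds, is how far beyond that limit either chain lies. Also open, on these data alone, is whether a phenyl ring carrying the dimethylcarbamoyl group, or a longer chain ending in an amine, would bring the number back towards the ring compounds.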